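This account rests on a few compounds, and the source may have more. Where it says the series, first, only, none or still open, it means among the compounds named here.

Among the compounds with values here, in an assay on isolated protein for displacement of a labelled ligand from Oxytocin receptor (Homo sapiens) (on this read-out higher numbers stand for weaker inhibition and lower numbers for stronger inhibition), the three compounds measured so far span a wide range. Compound 1, `CC[C@H](C)[C@@H]1C(=O)N[C@H](C2Cc3ccccc3C2)C(=O)N1[C@@H](C(=O)N1CCOCC1)c1cnc(C)cc1C`, gives 0.0501 nM. Compound 2, `CC[C@H](C)[C@@H]1C(=O)N[C@H](C2Cc3ccccc3C2)C(=O)N1[C@@H](C(=O)N(C)C)c1ccc(C)[n+]([O-])c1`, gives 1 nM. Compound 3, `CC(C)C[C@@H]1C(=O)N[C@H](C2Cc3ccccc3C2)C(=O)N1[C@@H](C(=O)N(C)C)c1ccc(O)nc1`, gives 3.16 nM. On this assay compound 3 therefore stands at the highest number of the three, which here means the weakest inhibition; its nearest neighbour is compound 2, and the largest distance is to compound 1, both gaps lying beyond the scatter of repeated measurements.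

Compound 4, `COc1ccc([C@H](C(=O)N(C)C)N2C(=O)[C@@H](C3Cc4ccccc4C3)NC(=O)[C@H]2CC(C)C)cn1`, has not yet been measured. It differs from compound 3 in a single place: methyl in place of hydrogen on an oxygen on an aromatic ring. Everything else in the shared core, including the leucine-derived side chain and the dimethylamide, stays the same.

Within the data shown here, no pair among the measured compounds differs in only this one place, so there is no directly comparable step to lean on. The expectation is a modest move toward stronger inhibition, a 2.1-fold lower number from compound 3 to compound 4 (0.32 log units; beyond the scatter), a step that could still fall within the usual scatter. On that basis compound 4 is estimated to give about 1.5 nM in this assay, with a plausible range from 0.4 nM to 5 nM.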

Compound 4, inhibition constant in the Oxytocin receptor assay: 0.398 nM
Beside the measured number, compound 4's estimate is 3.8-fold (0.58 log units) above it, outside the stated range (below it).
By their numbers in the Oxytocin receptor assay, from the lowest: compound 1; then compound 4; then compound 2; then compound 3.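

In the Oxytocin receptor assay, turning 6-hydroxypyridin-3-yl into 6-methoxypyridin-3-yl gives a 7.9-fold lower number from compound 3 to compound 4 (0.90 log units; beyond the scatter). Within the data shown here, this is the first direct reading of a single change: one methyl on this oxygen is enough to shift the binding result, and the hydrogen on that oxygen is not needed for strong inhibition. In a physicochemical assay for lipophilicity, read by HPLC (a higher number here means a more lipophilic compound, a lower number a more polar compound), compound 3 gives 1.3 and compound 4 gives 2.7 after the change. The same change also moves the compound clearly toward the lipophilic end of the physicochemical assay: the measured distribution coefficient of compound 3, 1.3, and of compound 4, 2.7, a number 1.40 log units higher (beyond the scatter)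

Both numbers shift together here, but a single pair cannot tell whether those two shifts are linked or simply happen at the same time. The compounds shown leave open whether a longer chain on this oxygen, such as ethoxy, would carry the trend further, whether an amine in place of the methoxy would keep the stronger inhibition, and whether the same step would hold on the cores of compound 1 and compound 2.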